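This account rests on a few compounds, and the source may have more. Where it says the series, first, only, none or still open, it means among the compounds named here.

Measured in a functional assay on HL-60 cells (Homo sapiens) for antiproliferative activity, read by MTT assay, with a stated time of 72 h; on this read-out higher numbers stand for weaker inhibition and lower numbers for stronger inhibition:
- Compound 1 `C=C(Br)C(=O)Nc1ccc2c(c1)/C(=C/c1cccs1)C(=O)N2`: 230 nM
- Compound 2 `C=C(Br)C(=O)Nc1ccc2c(c1)/C(=C/c1ccc(C)s1)C(=O)N2`: 24 nM

Compound 2 has the lower of these two numbers, so it is the stronger inhibitor of the pair. Compound 3 `C=C(Br)C(=O)Nc1ccc2c(c1)/C(=C/c1sccc1C)C(=O)N2` has the same atoms joined differently: 3-methylthiophen-2-yl in place of 5-methylthiophen-2-yl on a double-bonded chain carbon bound to a double-bonded ring carbon. The swap is 3-methylthiophen-2-yl in place of 5-methylthiophen-2-yl. Going by the values given here, the only measured step that bears on this is a 9.6-fold lower number from compound 1 to compound 2 (0.98 log units; beyond the scatter), with methyl in place of hydrogen on an aromatic carbon. Compound 3 keeps the methyl, but no measurement tests its new place, so part of that gain may be lost. A modest rise is expected, a 2.5-fold higher number from compound 2 to compound 3 (0.40 log units; beyond the scatter). For compound 3 the estimated value is 60 nM, with a range of 15 nM to 240 nM.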

Compound 3, half-maximal inhibitory concentration: 13 nM
Compound 3: the middle estimate sits 4.6-fold (0.66 log units) above what was measured; measured number below the stated range.
By their numbers in this assay, from the lowest: compounds 3 and 2 (each within the scatter of the next); then compound 1.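

In this assay, swapping 5-methylthiophen-2-yl for 3-methylthiophen-2-yl gives a 1.8-fold lower number from compound 2 to compound 3 (0.27 log units; within the scatter) and so leaves the number unchanged within normal variation. The benefit of adding a methyl is therefore not tied to a single place on the thiophene, since the data show an 18-fold lower number from compound 1 to compound 3 (1.25 log units; beyond the scatter) when the methyl is in its new place. No supporting measurement explains this result. Still open, going by these compounds, is whether 4-methylthiophen-2-yl would match these two compounds. It is also unknown whether an ethyl group, an amine or a carboxylic acid could take the place of the methyl.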